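The source may hold more compounds than are shown below. What is called first, only, known or untested is meant among the compounds shown, and "the series" means these compounds.

Measured so far:
- compound 1 `c1ccc(CN2CCN(CCCc3c[nH]c4ccc(-n5cnnc5)cc34)CC2)nc1`, 18 nM in an assay on CHO cells for displacement of a labelled ligand from 5-hydroxytryptamine receptor 1B (Homo sapiens); a higher number here means a weaker inhibitor, a lower number a stronger inhibitor
- compound 2 `CC(=O)Nc1ccc(CN2CCN(CCCc3c[nH]c4ccc(-n5cnnc5)cc34)CC2)cc1`, 56 nM

Both numbers come from the same test. For the measured compounds named here, compound 2 gives the higher of the two, that is, it is the weaker of the pair; its only neighbour is compound 1, and the gap between them is a 3.1-fold higher number from compound 1 to compound 2 (0.49 log units; beyond the scatter), a modest but real difference.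

Compound 3 `CN1CCN(CCCc2c[nH]c3ccc(-n4cnnc4)cc23)CC1` is not yet measured. It differs from compound 2 by a single change: hydrogen in place of 4-acetamidophenyl on a saturated chain carbon bound to an amine nitrogen in a ring. Where compound 2 carries a whole aromatic ring with an acetamide on it, compound 3 carries only a hydrogen, so the chain end shrinks from 4-acetamidobenzyl to methyl.

Going by the values given here, only one measured step gives any guidance. The change from compound 1 to compound 2 swapped one aromatic ring for another and moved the number by a 3.1-fold higher number from compound 1 to compound 2 (0.49 log units; beyond the scatter). Among the compounds with values here, removing the ring altogether is a larger change than that swap, and there is no measured pair that shows what such a removal does. The expectation is therefore a further rise in the number, larger than the swap produced, though with wide uncertainty. For compound 3 the estimate in this assay is 300 nM, with a likely range of 80 nM to 1500 nM, corresponding to an expected step of a 5.4-fold higher number from compound 2 to compound 3 (0.73 log units; beyond the scatter).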

Compound 3, half-maximal inhibitory concentration: 309 nM
The estimate for compound 3 lay 1.0-fold (0.01 log units) below the measured number; measured number inside the range.
By their numbers in this assay, from the lowest: compound 1; then compound 2; then compound 3.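

In this assay, replacing the 4-acetamidophenyl with hydrogen, which shortens the chain end to methyl, gives a 5.5-fold higher number from compound 2 to compound 3 (0.74 log units; beyond the scatter), while the same replacement of pyridin-2-yl gives a 17-fold higher number from compound 1 to compound 3 (1.23 log units; beyond the scatter), a step printed as large. For the compounds shown here, until now the only comparison at this position was one aromatic ring against another, whereas the methyl compound now provides a reference without any ring, and both ring-bearing compounds give lower numbers than it does, with none of the three going against this pattern. The ring-for-ring swap, a 3.1-fold higher number from compound 1 to compound 2 (0.49 log units; beyond the scatter), therefore reads as a modest adjustment within a series where having a ring at all goes with the stronger inhibitors, though nothing available explains why.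

From the compounds shown here alone, what remains open is whether the aromatic character of the ring matters or simply the presence of a larger group, a question that a cyclohexylmethyl group at this position could help to answer. A plain benzyl group would likewise show how much of the difference among the ring-bearing compounds comes from the acetamide and how much from the ring itself.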